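Chloro Substitution on the Amide Nitrogen Aryl Group

The source may report more compounds than this note shows. Statements on the series, on what has been measured and on what is new or still open speak of the compounds shown alone.

Compound 1, `CC1(C)C(=O)N(Cc2ccccc2)c2ncccc21`, gives 12%.
Compound 2, `CC1(C)C(=O)N(Cc2ccc(Cl)cc2)c2ncccc21`, gives 0%.
Compound 3, `CC1(C)C(=O)N(c2cccc(Cl)c2)c2ncccc21`, gives 49%.

All three were tested in a functional assay on the whole organism (Pleural cavity) for inhibition, with Rattus norvegicus as the target, at a dose of 25 mg/kg; a higher number here means more inhibition at the dose given (going by the name of the read-out), a lower number less inhibition. Compound 1 and compound 2 share a core and differ by chloro in place of hydrogen on an aromatic carbon; this change made a step of a number 12 percentage points lower from compound 1 to compound 2 (beyond the scatter). Compound 3 carries a different group on the amide nitrogen, and the difference between its core and that of compound 1 is not broken down here; what the values show is that compound 3 stands highest of the three, with compound 1 and compound 2 lying below it by more than the scatter. Compound 4, `CC1(C)C(=O)N(c2cc(Cl)cc(Cl)c2)c2ncccc21`, is not yet measured. It differs from compound 3 by chloro in place of hydrogen on an aromatic carbon. This is the same kind of change as from compound 1 to compound 2, but the place is not the same: in compound 2 the chloro sits para to a large group, while in compound 4 it sits meta to a chloro group and meta to a large group. Resting on the step of a number 12 percentage points lower from compound 1 to compound 2 (beyond the scatter), compound 4 is expected to show a step of a number 11 percentage points lower from compound 3 to compound 4 (beyond the scatter) in this assay. Compound 4 is thus estimated at 38%, between 15% and 60%.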

Compound 4, a percentage reported as inhibition, in the whole organism at one dose (the size of the read-out at that dose, not a potency): 33%
The estimate for compound 4 lay 5 percentage points above the measured number; the measured number falls inside the stated range.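

In this assay, chloro in place of hydrogen on an aromatic carbon gave a number 16 percentage points lower from compound 3 to compound 4 (beyond the scatter), so the added chloro, meta to a chloro group and meta to a large group, went with less inhibition at the dose given. Set beside the earlier case, the change carried from one core to the other in the same direction and with a size that cannot be told apart: the same change on two cores in this assay, a number 12 percentage points lower (beyond the scatter) from compound 1 to compound 2 and a number 16 percentage points lower (beyond the scatter) from compound 3 to compound 4, 4 percentage points apart, within the scatter of two such steps This agreement rests on only two pairs, however, and it does not show that the step would hold on other cores or at other places on the ring.

The compounds shown carry only chloro as an added group, which leaves open how an amine, a methoxy group or a trifluoromethyl group at the same place would read in this assay. They also leave open what a longer chain on the amide nitrogen would do to the number.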